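Nitro in place of amino on compound 2

The source may hold more compounds than are shown below. What is called first, only, known or untested is meant among the compounds shown, and "the series" means these compounds.

In a functional assay on HL-60 cells (Homo sapiens) for cytotoxicity, read by XTT assay, with a stated time of 72 h (on this read-out lower numbers stand for stronger inhibition and higher numbers for weaker inhibition), compound 1 `COc1ccc(C(=O)c2cc(OC)c(OC)c(OC)c2)cc1[N+](=O)[O-]` gives 1800 nM, and compound 2 `COc1ccc(Cc2ccc(OC)c(OC)c2OC)cc1N` gives 230 nM, the lower of the two numbers and separated from compound 1 by more than the scatter. Compound 3 `CCn1ccc2cc(C(O)c3ccc(OC)c(OC)c3OC)ccc21` gives > 10000 nM, which is a limit of the assay and not a number. Compound 4 `COc1ccc(Cc2ccc(OC)c(OC)c2OC)cc1[N+](=O)[O-]` differs from compound 2 by nitro in place of amino on an aromatic carbon. Among the compounds with values here, no measured pair isolates this change. Compound 1, which also carries a nitro group but has a different core, stands at 1800 nM, so weaker inhibition is expected. The expected step of a 5.2-fold higher number from compound 2 to compound 4 (0.72 log units; beyond the scatter) lies beyond the scatter, toward a higher number. Compound 4 is estimated at 1200 nM, with an expected range of 300 nM to 5000 nM.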

Compound 4, half-maximal inhibitory concentration: 2600 nM
Compound 4: middle estimate off by 2.2-fold (0.34 log units), on the low side; the range from low to high includes it.
By their numbers in this assay, from the lowest: compound 2; then compounds 1 and 4 (each within the scatter of the next). At a limit, above all of these: compound 3.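

In this assay, the change from amino to nitro, ortho to a methoxy group on the shared core, gives an 11-fold higher number from compound 2 to compound 4 (1.05 log units; beyond the scatter), a large step toward weaker inhibition. Within the data shown here, this is the only measured pair that isolates the change, so the amino group at this position can now be tied directly to the stronger inhibition of compound 2. No measured property shown here bears on this step. Going by these compounds, it remains open whether a hydroxyl group, a methylamino group or an acetamide at this position would match amino or nitro. On these data alone, whether the same step holds on the core of compound 1 also remains open.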